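This account rests on a few compounds, and the source may have more. Where it says the series, first, only, none or still open, it means among the compounds named here.

Compound 1, `ClCc1ccccc1Cn1cnc2c(Cl)nc(Cl)nc21`, is one of a small set built on a shared core that carries two chloro groups, joined to a benzyl arm bearing a chloromethyl group, and in a functional assay on SK-OV-3 cells (Homo sapiens) for cytotoxicity, read by sulforhodamine B assay, with a stated time of 48 h (on this read-out lower numbers stand for stronger inhibition of growth and higher numbers for weaker inhibition of growth), compound 1 gives 3540 nM. Compound 2, `ClCc1ccc(Cn2cnc3nc(Cl)nc(Cl)c32)cc1`, keeps the same core and places the chloromethyl arm elsewhere on the benzyl ring; in this assay compound 2 gives 5010 nM. The two numbers sit within the scatter of each other, so neither compound can be called the stronger or the weaker one. Compound 3, `ClCc1cccc(Cn2cnc3nc(Cl)nc(Cl)c32)c1`, a third placement of the same arm, has no number in this assay: compound 3 gives "not determined" (no result reported).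

Compound 4, `Nc1nc(Cl)c2ncn(Cc3ccccc3CCl)c2n1`, changes the core rather than the arm: amino in place of chloro on an aromatic carbon. Among the measured compounds shown here, no measured pair in the set shares this kind of swap, so there is no step to lean on. The expectation is therefore cautious: a change of modest size, with the number for compound 4 somewhat more likely to rise than to fall. Compound 4 is expected to reach 5500 nM, with a range from 1500 nM to 18000 nM. The estimated step from compound 1 to compound 4 is a 1.6-fold higher number from compound 1 to compound 4 (0.19 log units; within the scatter), a step that may well stay inside the scatter.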

Compound 4, concentration for total growth inhibition: 52500 nM
The estimate for compound 4 lay 9.5-fold (0.98 log units) below the measured number; measured number above the stated range.
By their numbers in this assay, from the lowest: compounds 1 and 2 (each within the scatter of the next); then compound 4.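

Moving the chloromethyl arm around the benzyl ring gave two numbers that cannot be told apart, but the first change to the core itself, amino in place of chloro, brings (a 15-fold higher number from compound 1 to compound 4 (1.17 log units; beyond the scatter)) in this assay, which on this read-out means much weaker inhibition of growth. So the aromatic carbon between two ring nitrogen atoms is a place where a single swap counts for far more than anything the earlier compounds could show, even though one heavy atom simply replaces another and the count changes only by one hydrogen-bond donor and one hydrogen-bond acceptor. Nothing measured here explains why this swap costs so much, so the step stands as an observation without a cause.

On these data alone, it remains open whether the drop belongs to the amino group itself or would follow any loss of chloro at this carbon, as a methoxy group, a methyl group or a plain hydrogen there could tell. As far as these compounds go, it is also open whether amino on the other chloro-bearing carbon, or the same swap with the arm placed as in compound 2, would give a step of similar size.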